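The source may report more compounds than this note shows. Statements on the series, on what has been measured and on what is new or still open speak of the compounds shown alone.

Measured in an ADME assay on Vero cells (Chlorocebus sabaeus) for cytotoxicity; a higher number here means that more compound is tolerated, a lower number that less compound is tolerated:
compound 1 `Fc1ccc(-c2nn3ccc(Cl)cc3c2-c2ccnc(NC3CCCC3)n2)cc1` — > 40000 nM, a limit of this assay
compound 2 `COCCNc1ccn2nc(-c3ccc(F)cc3)c(-c3ccnc(NC4CCCC4)n3)c2c1` — > 40000 nM, a limit of this assay

Compound 1 stands only at that limit in this assay, not at a number. For the measured compounds named here, the one measured step, from compound 1 to compound 2, is a step that the two limits leave unreadable from compound 1 to compound 2, with (2-methoxyethyl)amino in place of chloro on an aromatic carbon; both values sit at the limit of > 40000 nM in this assay, at which 2 of the 2 values shown sit. Compound 3 `Fc1ccc(-c2nn3c(NC4CC4)cc(Cl)cc3c2-c2ccnc(NC3CCCC3)n2)cc1` differs from compound 1 by cyclopropylamino in place of hydrogen on an aromatic carbon. No measured step bears on this change, and the one step shown is unreadable. Compound 3 is therefore expected to sit near the same limit, a step of a number no higher from compound 1 to compound 3 (the limit leaves the size open). Estimate for compound 3: 40000 nM, range 15000 nM to 100000 nM.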

Compound 3, half-maximal cytotoxic concentration: > 40000 nM
Compound 3: no number, only a limit; the forecaster's own chance of this, stated with the estimate: 60%; the middle value sits exactly at the limit.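

In this assay, for the compounds shown here, compound 3 gives > 40000 nM, a limit and not a number, so no step between compound 1 and compound 3 can be read. The compounds shown leave open whether cyclopropylamino or (2-methoxyethyl)amino changes cytotoxicity at all, since all values sit at one limit: the limit of > 40000 nM in this assay, at which 3 of the 3 values shown sit.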